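The source may hold more compounds than are shown below. What is called first, only, known or untested is meant among the compounds shown, and "the series" means these compounds.

Working notes on the series, read in a functional assay on NCI-H460 cells (Homo sapiens) for cytotoxicity, read by sulforhodamine B assay, with a stated time of 3 days; on this read-out higher numbers stand for weaker inhibition and lower numbers for stronger inhibition. Of the compounds shown here, three have numbers so far. Compound 1 `O=Cc1cn(Cc2ccc(Cl)cc2Cl)c2ccccc12` gives 100 nM and compound 2 `OCc1cn(Cc2ccccc2Cl)c2ccccc12` also gives 100 nM, so these two cannot be told apart. Compound 3 `OCc1cn(Cc2ccc(Cl)cc2)c2ccccc12` gives 16 nM, the lowest number of the three, and the gap to each of the other two lies beyond the usual scatter.

The next step runs from compound 3 to compound 4 `OCc1cn(Cc2ccc(Cl)cc2Cl)c2ccccc12`. The structural change is chloro in place of hydrogen on an aromatic carbon, ortho to a large group and meta to the chloro group already present.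

Within the data shown here, no measured pair isolates this change, so the expectation rests on indirect evidence. The ring substitution of compound 4 recurs in compound 1, which gives 100 nM. Set against compound 3, chloro stands at a different place on the ring in compound 2, which gives 100 nM. Both numbers sit higher than that of compound 3, so a moderate move toward weaker inhibition is expected, possibly not much beyond the scatter, with an estimated 2.2-fold higher number from compound 3 to compound 4 (0.34 log units; beyond the scatter). For compound 4 the estimated value is 35 nM, with an expected range of 12 nM to 100 nM.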

Compound 4, half-maximal inhibitory concentration: 79 nM
The estimate for compound 4 lay 2.3-fold (0.35 log units) below the measured number, and the stated range covers the measured number.
By their numbers in this assay, from the lowest: compound 3; then compounds 4, 1 and 2 (each within the scatter of the next).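

In this assay, among these compounds, chloro in place of hydrogen on an aromatic carbon, ortho to a large group and meta to the chloro group already present, gives a 4.9-fold higher number from compound 3 to compound 4 (0.69 log units; beyond the scatter), so this position does not tolerate the added chloro without a loss of inhibition, a point that the earlier compounds could suggest only indirectly. The same kind of change, applied to a different starting compound, gives a 1.3-fold lower number from compound 2 to compound 4 (0.10 log units; within the scatter), and hydroxymethyl in place of formyl gives a 1.3-fold lower number from compound 1 to compound 4 (0.10 log units; within the scatter); both steps lie within the scatter, so neither change can be distinguished from no change in these pairs. No available evidence bears on the reason for the step from the monochloro compound to the dichloro compound.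

Going by these compounds, whether fluoro, methyl or methoxy at the same place would give a step of similar size remains open, so the result cannot yet be read as a general feature of substitution there. Also open, on these data alone, is how an aminomethyl group or a carboxylic acid in place of hydroxymethyl would read, with or without the added chloro.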